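Adding a Second Chloro Group: Expected Kinetic Solubility

This account rests on a few compounds, and the source may have more. Where it says the series, first, only, none or still open, it means among the compounds named here.

Compound 1 `O=C(Nc1cccc(-c2nc3ccccc3s2)c1)c1cnccc1Cl` gives 320 nM in a physicochemical assay for solubility, in phosphate buffer, measured as kinetic solubility, with a stated time of 18 h, at pH 7.4; a higher number here means a more soluble compound, a lower number a less soluble compound.
Compound 2 `O=C(Nc1cccc(-c2nc3ccccc3s2)c1)c1cccnc1Cl` gives 520 nM in this assay.

Going by the values given here, only two numbers have been measured so far, and compound 2 is the starting point for the next step. Its single neighbour is compound 1, and a 1.6-fold higher number from compound 1 to compound 2 (0.21 log units; within the scatter), so the two read alike within the scatter of this assay; moving the chloro group around the ring has shown no clear effect.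

Compound 3 `O=C(Nc1cccc(-c2nc3ccccc3s2)c1)c1ccc(Cl)nc1Cl` has not yet been measured. It differs from compound 2 by chloro in place of hydrogen on an aromatic carbon. Among the compounds with values here, no measured step adds a chloro group; the one step that exists, from compound 1 to compound 2, only shifts one, and it was within the scatter. There is therefore no direct guide, and the expectation can only be cautious: a small step in this assay, possibly none beyond the scatter. The estimate for compound 3 is 350 nM, with a range from 120 nM to 1000 nM, which means an expected step of a 1.5-fold lower number from compound 2 to compound 3 (0.17 log units; within the scatter).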

Compound 3, solubility: 350 nM
For compound 3 middle estimate and measured number coincide at the digits printed; measured number inside the range.
By their numbers in this assay, from the lowest: compounds 1, 3 and 2 (each within the scatter of the next).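

Going by these compounds alone, this is the first step that adds a chloro group rather than shifting one: chloro in place of hydrogen on the aromatic carbon next to the ring nitrogen gives a 1.5-fold lower number from compound 2 to compound 3 (0.17 log units; within the scatter) in this assay, so this position accepts a second chloro group with no change that stands clear of the scatter. Setting the 2,6-dichloropyridin-3-yl group against the 4-chloropyridin-3-yl group gives a 1.1-fold higher number from compound 1 to compound 3 (0.04 log units; within the scatter), which means that the three substitution patterns on this ring, with one chloro group or with two, cannot yet be told apart in this assay. No other measurement bears on this result, so nothing can be said about what lies behind it.

What remains open is whether any group on this same aromatic carbon can move the number beyond the scatter, for instance an amine or a carboxylic acid, neither of which is among the compounds shown. As far as these compounds go, it is also open whether the shared core sets the level of these numbers, since all three compounds carry it and only the chloro groups on the pyridine ring differ among them.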